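Shifting Two Fluorines on the Phenoxy Group

A few compounds are considered here, and "the series" means these few. Any claim that something is new, unique, unknown or untested is made for them only; others in the source may bear on it.

Compound 1 `CC(C)[C@H](NC(=O)COc1cccc2ccccc12)C(=O)N[C@@H](CC(=O)O)C(=O)COc1ccccc1F` gives 15700 nM
Compound 2 `CC(C)[C@H](NC(=O)COc1cccc2ccccc12)C(=O)N[C@@H](CC(=O)O)C(=O)COc1cccc(F)c1` gives 12000 nM
Compound 3 `CC(C)[C@H](NC(=O)COc1cccc2ccccc12)C(=O)N[C@@H](CC(=O)O)C(=O)COc1cc(F)ccc1F` gives 19700 nM
Compound 4 `CC(C)[C@H](NC(=O)COc1cccc2ccccc12)C(=O)N[C@@H](CC(=O)O)C(=O)COc1ccc(F)c(F)c1` is not yet measured

In a functional assay with Homo sapiens as the target (a higher number here means a weaker inhibitor, a lower number a stronger inhibitor), compound 3 gives 19700 nM and cannot be told apart from compound 1 or compound 2, since all three values lie within the scatter of each other. The next change is 3,4-difluorophenyl in place of 2,5-difluorophenyl on an oxygen on a saturated carbon with 3,4-difluorophenyl in place of 2,5-difluorophenyl on an oxygen on a saturated carbon. Three measured steps in the same group bear on it. Exchanging 2-fluorophenyl for 3-fluorophenyl gave a 1.3-fold lower number from compound 1 to compound 2 (0.12 log units; within the scatter) while adding a second fluoro gave a 1.3-fold higher number from compound 1 to compound 3 (0.10 log units; within the scatter) and a 1.6-fold higher number from compound 2 to compound 3 (0.22 log units; within the scatter) with all three inside the scatter. No step beyond the scatter is therefore expected in this assay. What is expected is a 1.3-fold lower number from compound 3 to compound 4 (0.12 log units; within the scatter) and nothing larger. Compound 4 is estimated at 15000 nM (expected range 8500 nM to 26000 nM).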

Compound 4, half-maximal inhibitory concentration: 16200 nM
Compound 4: the middle estimate sits 1.1-fold (0.03 log units) below what was measured; the range from low to high includes it.
By their numbers in this assay, from the lowest: compounds 2, 1, 4 and 3 (each within the scatter of the next).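

Swapping 2,5-difluorophenyl for 3,4-difluorophenyl gives a 1.2-fold lower number from compound 3 to compound 4 (0.08 log units; within the scatter) in this assay, so rearranging both fluorines together has no measurable effect here. Set against the compounds with one fluoro, compound 4 also stays close, with a 1.4-fold higher number from compound 2 to compound 4 (0.13 log units; within the scatter) and a 1.0-fold higher number from compound 1 to compound 4 (0.01 log units; within the scatter). Adding a fluoro on an aromatic carbon now reads alike in two separate comparisons: the same change on two cores in this assay, a 1.3-fold higher number (0.10 log units; within the scatter) from compound 1 to compound 3 and a 1.4-fold higher number (0.13 log units; within the scatter) from compound 2 to compound 4, 1.1-fold (0.03 log units) apart, within the scatter of two such steps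

All four compounds carry only fluoro on this phenyl ring. As far as these compounds go, whether an amine or a methoxy group there would produce a step beyond the scatter remains open.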